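The source may hold more compounds than are shown below. What is called first, only, known or untested is meant among the compounds shown, and "the series" means these compounds.

Of the compounds shown here, two have been measured so far in a functional assay on NCI-H460 cells (Homo sapiens) for inhibition, with a stated time of 72 h; a lower number here means a stronger inhibitor, a higher number a weaker inhibitor.

Compound 1 `COc1ccc(S(=O)(=O)N2CCc3cccc(-c4ccc(N)cc4)c32)cc1` gives 288 nM
Compound 2 `COc1ccc(-c2cccc3c2N(S(=O)(=O)c2ccc(OC)cc2)CC3)cc1` gives 302 nM

Within the data shown here, compound 2 stands level with compound 1, the only other measured compound, as the two values lie within the scatter of each other. The move to compound 3 `COc1ccc(S(=O)(=O)N2CCc3cccc(-c4ccccc4)c32)cc1` is hydrogen in place of methoxy on an aromatic carbon. Among the measured compounds shown here, the one measured step that bears on it, a 1.0-fold higher number from compound 1 to compound 2 (0.02 log units; within the scatter), is methoxy in place of amino on an aromatic carbon and stays within the scatter. For the measured compounds named here, no measured compound carries hydrogen there, so the evidence is thin, but no step beyond the scatter is expected in this assay. The estimated change is a 1.1-fold higher number from compound 2 to compound 3 (0.04 log units; within the scatter). For compound 3 the estimate is 330 nM, with an expected range from 140 nM to 750 nM.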

Compound 3, half-maximal inhibitory concentration: 213 nM
Beside the measured number, compound 3's estimate is 1.5-fold (0.19 log units) above it; the measured number falls inside the stated range.
By their numbers in this assay, from the lowest: compounds 3, 1 and 2 (each within the scatter of the next).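

In this assay, the position on the aromatic ring para to a large group now also carries plain hydrogen, and this stays within the scatter for both substituents: methoxy (a 1.4-fold lower number from compound 2 to compound 3 (0.15 log units; within the scatter)) and amino (a 1.4-fold lower number from compound 1 to compound 3 (0.13 log units; within the scatter)). The substituent at this place thus need not be present at all for the values to stay level across the three compounds. No measurement shown offers any explanation for this result. The compounds shown leave open whether a carboxylic acid, trifluoromethyl or a longer chain at this place would give a step beyond the scatter.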